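The compounds below may be only part of what the source reports. "The series", "measured", "known", "first", "only" and "open" are said of these compounds alone.

Measured so far in an assay on LtK cells with ATP-sensitive inward rectifier potassium channel 11 (Homo sapiens) as the target; on this read-out lower numbers stand for an effect already at smaller amounts and higher numbers for an effect only at larger amounts of compound:
compound 1, `CCCC(=O)Nc1c(C(O)(C(F)(F)F)C(F)(F)F)ccc2ccccc12`: 131 nM
compound 2, `Cc1ccccc1C(=O)Nc1c(C(O)(C(F)(F)F)C(F)(F)F)ccc2ccccc12`: 5550 nM
compound 3, `O=C(Nc1c(C(O)(C(F)(F)F)C(F)(F)F)ccc2ccccc12)c1cnco1`: 24 nM

Compound 2 gives the highest number of the three in this assay; both steps away from it are large, a 42-fold higher number from compound 1 to compound 2 (1.63 log units; beyond the scatter) and a 230-fold lower number from compound 2 to compound 3 (2.36 log units; beyond the scatter), so its 2-methylphenyl on the carbonyl carbon is the weakest group seen at this place.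

Compound 4, `O=C(Nc1c(C(O)(C(F)(F)F)C(F)(F)F)ccc2ccccc12)c1cccnc1`, is not yet measured. Its change from compound 2: pyridin-3-yl in place of 2-methylphenyl on a carbonyl carbon. The step that bears most directly on it is a 230-fold lower number from compound 2 to compound 3 (2.36 log units; beyond the scatter), where 1,3-oxazol-5-yl replaced the same 2-methylphenyl on the carbonyl carbon; a 5.5-fold lower number from compound 1 to compound 3 (0.74 log units; beyond the scatter) and a 42-fold higher number from compound 1 to compound 2 (1.63 log units; beyond the scatter) place propyl between the two. The entering pyridin-3-yl is a six-membered aromatic ring with 1 hetero atom and no methyl, closer in that respect to compound 3 than to compound 2, so a large drop in the number is expected, though it need not reach compound 3. For compound 4 the expected step is a 37-fold lower number from compound 2 to compound 4 (1.57 log units; beyond the scatter). The estimate for compound 4 in this assay is 150 nM, with a range of 30 nM to 800 nM.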

Compound 4, half-maximal effective concentration: 60 nM
Beside the measured number, compound 4's estimate is 2.5-fold (0.40 log units) above it, and the stated range covers the measured number.
By their numbers in this assay, from the lowest: compound 3; then compound 4; then compound 1; then compound 2.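

In this assay, a six-membered aromatic ring on the carbonyl carbon is compatible with a low number, as pyridin-3-yl in place of 2-methylphenyl gives a large drop (a 93-fold lower number from compound 2 to compound 4 (1.97 log units; beyond the scatter)). Pyridin-3-yl also gives a lower number than propyl (a 2.2-fold lower number from compound 1 to compound 4 (0.34 log units; beyond the scatter)) but a higher one than 1,3-oxazol-5-yl (a 2.5-fold higher number from compound 3 to compound 4 (0.40 log units; beyond the scatter)), so the two rings with hetero atoms lead this set, with propyl next and 2-methylphenyl last, all gaps beyond the scatter. Nothing in the available data accounts for this order.

On these data alone, the step from 2-methylphenyl to pyridin-3-yl removes the methyl and adds the ring nitrogen together, so their separate shares remain open. Plain phenyl and 2-methylpyridin-3-yl on the same carbonyl carbon would separate them.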